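A few compounds are considered here, and "the series" means these few. Any claim that something is new, unique, unknown or untested is made for them only; others in the source may bear on it.

Compound 2 `COc1cc2ncnc(Nc3cccc(F)c3)c2cc1OCCCCC(=O)Nc1ccc(S(N)(=O)=O)cc1` gives 29900 nM in a functional assay on A-431 cells (Homo sapiens) for antiproliferative activity, read by MTT assay, with a stated time of 72 h (a lower number here means a stronger inhibitor, a higher number a weaker inhibitor), the higher of the two numbers recorded, with compound 1 `C#Cc1cccc(Nc2ncnc3cc(OC)c(OCCCCC(=O)Nc4ccc(S(N)(=O)=O)cc4)cc23)c1` at 17700 nM as its only comparator. Among the measured compounds shown here, the step from compound 1 to compound 2 was a 1.7-fold higher number from compound 1 to compound 2 (0.23 log units; within the scatter), so the single change seen so far left the number essentially unmoved. Compound 3 `COc1ccc(Nc2ncnc3cc(OC)c(OCCCCC(=O)Nc4ccc(S(N)(=O)=O)cc4)cc23)cc1` differs from compound 2 by 4-methoxyphenyl in place of 3-fluorophenyl on a nitrogen on an aromatic ring. For the measured compounds named here, no measured step touches the aromatic ring entering here, so nothing speaks for a shift in this assay beyond the scatter. Compound 3 is therefore expected at about 40000 nM, with a range from 15000 nM to 110000 nM, a step of a 1.3-fold higher number from compound 2 to compound 3 (0.13 log units; within the scatter) that is an estimate only.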

Compound 3, half-maximal inhibitory concentration: 14700 nM
Estimate against measurement, compound 3: 2.7-fold (0.43 log units) above, and the stated range ends above it.
By their numbers in this assay, from the lowest: compounds 3, 1 and 2 (each within the scatter of the next, the first and the last beyond it).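

With 4-methoxyphenyl in place of 3-fluorophenyl on a nitrogen on an aromatic ring, this assay shows its first step beyond the scatter, a 2.0-fold lower number from compound 2 to compound 3 (0.31 log units; beyond the scatter), though only a modest one. Against the 3-ethynylphenyl group of compound 1, the same 4-methoxyphenyl group gives a 1.2-fold lower number from compound 1 to compound 3 (0.08 log units; within the scatter), so this pair stays within the scatter and the position shows no clear ranking of these groups. No evidence on hand accounts for either step.

Left open is how an amine or a carboxylic acid on this aromatic ring would read in this assay. Also open, on these data alone, is whether any such group would move the number further than these steps.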